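Methoxy for hydroxyl on the aryl arm of the series

A few compounds are considered here, and "the series" means these few. Any claim that something is new, unique, unknown or untested is made for them only; others in the source may bear on it.

Working notes on three measured compounds and one still to come. In an assay on S100 cells for inhibition of Polyunsaturated fatty acid 5-lipoxygenase (Homo sapiens), read by HPLC, with stated times of 15 min and 10 min (a higher number here means a weaker inhibitor, a lower number a stronger inhibitor), compound 2 `Cc1ccc2nc(-c3ccccc3O)c(NC3CCCCC3)n2c1` gives 1800 nM, second highest of the three numbers. Within the data shown here, compound 3 `Cc1ccc2nc(-c3ccncc3)c(NC3CCCCC3)n2c1` gives 7700 nM in this assay, and compound 1 `Clc1ccc2nc(-c3ccc(N4CCCCC4)cc3)c(NC3CCCCC3)n2c1` gives 60 nM; compound 1 differs from compound 2 in two places, so no single-point step links them, and the value of compound 1 stands only as a point of comparison. Among the measured compounds shown here, the one single-point step measured so far is a 4.3-fold higher number from compound 2 to compound 3 (0.63 log units; beyond the scatter).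

Compound 4 `COc1cccc(-c2nc3ccc(C)cn3c2NC2CCCCC2)c1` differs from compound 2 as follows: 3-methoxyphenyl in place of 2-hydroxyphenyl on an aromatic carbon. The step from compound 2 to compound 3 shows that replacing the 2-hydroxyphenyl can weaken inhibition by a modest margin, but compound 3 carries a pyridin-4-yl rather than a 3-methoxyphenyl, so it bears only loosely on the present change; the drop to 0 hydrogen-bond donors is the one counted feature the two changes share. A small step toward a higher number, or none beyond the scatter, is therefore expected, a 1.4-fold higher number from compound 2 to compound 4 (0.14 log units; within the scatter). For compound 4 in this assay the estimate is 2500 nM, within a range of 600 nM to 10000 nM.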

Compound 4, half-maximal inhibitory concentration: 430 nM
Beside the measured number, compound 4's estimate is 5.8-fold (0.76 log units) above it; measured number below the stated range.
By their numbers in this assay, from the lowest: compound 1; then compound 4; then compound 2; then compound 3.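

In this assay, the aryl arm at this position can move the number down as well as up: a 4.2-fold lower number from compound 2 to compound 4 (0.62 log units; beyond the scatter), against a 4.3-fold higher number from compound 2 to compound 3 (0.63 log units; beyond the scatter). Both changes drop to 0 hydrogen-bond donors yet run in opposite directions, so that count alone does not track the number across compounds 2, 3 and 4, and the choice of arm matters a good deal, with an 18-fold lower number from compound 3 to compound 4 (1.25 log units; beyond the scatter). No measurement at hand accounts for either direction.

The change to compound 4 alters both the place of the oxygen on the phenyl ring and the group it carries, so the step cannot assign the gain to either one. From the compounds shown here alone, a 3-hydroxyphenyl or a 2-methoxyphenyl arm on the same core would separate the two, and whether a longer ether such as 3-ethoxyphenyl goes further remains open.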